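The source may hold more compounds than are shown below. What is called first, only, known or untested is meant among the compounds shown, and "the series" means these compounds.

In a functional assay on MDA-MB-435 cells (Homo sapiens) for antiproliferative activity (a lower number here means a stronger inhibitor of growth, a higher number a weaker inhibitor of growth), compound 1 `Cc1ccnc2nc(-c3cccc4ccccc34)cc(O)c12` gives < 10 nM, which is a limit of the assay and not a number. Among the compounds with values here, compound 2 `Cc1cc(C)c2c(O)cc(-c3cccc4ccccc34)nc2n1` gives 191 nM, the only actual number so far. Compound 3 `Cc1ccc2c(O)cc(-c3cccc4ccccc34)nc2n1` carries hydrogen in place of methyl on an aromatic carbon, opposite the ring nitrogen: hydrogen in place of methyl on an aromatic carbon. Within the data shown here, the one measured step, an at least 19-fold higher number from compound 1 to compound 2 (1.28 log units; beyond the scatter), is large and adds a methyl on a different aromatic carbon, so it bears only indirectly on this change. A moderate move to a lower number is expected, estimated as a 3.8-fold lower number from compound 2 to compound 3 (0.58 log units; beyond the scatter). For compound 3 the estimated value is 50 nM, with an expected range of 10 nM to 250 nM.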

Compound 3, concentration for 50% growth inhibition: < 10 nM
Compound 3: no number, only a limit (the forecaster's own chance of this, stated with the estimate: 20%); middle value at least 5.0-fold (0.69 log units) away from the limit.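

In this assay, hydrogen in place of methyl opposite the ring nitrogen gives an at least 19-fold lower number from compound 2 to compound 3 (1.28 log units; beyond the scatter), so this position, which earlier bore only indirectly on the change, now has its own large step. With an at least 19-fold higher number from compound 1 to compound 2 (1.28 log units; beyond the scatter), compound 2 is the only compound shown carrying both methyl groups, and it alone has a measured number. Compound 3 gives < 10 nM, which is a limit of the assay and not a number, so the step is a minimum: the limit of < 10 nM in this assay, at which 2 of the 3 values shown sit.

On these data alone, whether an ethyl, a methoxy or an amine at this position would behave like methyl or like hydrogen remains open.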